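The compounds below may be only part of what the source reports. "The series", "measured", "known", "first", "only" and "open" are said of these compounds alone.

In a functional assay on HeLa cells (Homo sapiens) for cytotoxicity, read by MTT assay; on this read-out lower numbers stand for stronger inhibition and higher numbers for weaker inhibition:
- compound 1 `CCCCC(O)CC(=O)O[C@H](CC=C(C)C)C1=CC(=O)c2c(O)ccc(O)c2C1=O`: 72200 nM
- compound 2 `CC(=O)OCCO[C@H](CC=C(C)C)C1=CC(=O)c2c(O)ccc(O)c2C1=O`: 41500 nM
- compound 3 `CC[C@](C)(O)CC(=O)O[C@H](CC=C(C)C)C1=CC(=O)c2c(O)ccc(O)c2C1=O`: not yet measured

Compound 2, at 41500 nM, lies within the scatter of compound 1, at 72200 nM, so neither can be ranked above the other. The next change, to compound 3, places (2-hydroxy-2-methylbutyl)carbonyl in place of 2-acetoxyethyl on an oxygen on a saturated carbon.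

Within the data shown here, only one measured step bears on this: a 1.7-fold lower number from compound 1 to compound 2 (0.24 log units; within the scatter). It exchanged (2-hydroxyhexyl)carbonyl for 2-acetoxyethyl at the same place, so the new change largely runs the other way, with a different carbonyl-bearing chain. With the measured step of a 1.7-fold lower number from compound 1 to compound 2 (0.24 log units; within the scatter) as the guide, no shift beyond the scatter is expected in this assay. The expected step is a 1.3-fold higher number from compound 2 to compound 3 (0.12 log units; within the scatter). For compound 3 the estimated value is 55000 nM, with an expected range of 22000 nM to 130000 nM.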

Compound 3, half-maximal inhibitory concentration: 30200 nM
For compound 3 the middle estimate is 1.8-fold (0.26 log units) above the measured one; the range from low to high includes it.
By their numbers in this assay, from the lowest: compounds 3, 2 and 1 (each within the scatter of the next, the first and the last beyond it).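

In this assay, placing (2-hydroxy-2-methylbutyl)carbonyl in place of 2-acetoxyethyl on the oxygen gives a 1.4-fold lower number from compound 2 to compound 3 (0.14 log units; within the scatter), so this exchange does not separate the two compounds. The ester chain itself does register: 1-hydroxy-1-methylpropyl in place of 1-hydroxypentyl on a saturated chain carbon bound to a carbonyl carbon gives a 2.4-fold lower number from compound 1 to compound 3 (0.38 log units; beyond the scatter), a modest step and the first at this position beyond the scatter. No supporting measurement bears on why this step occurs.

The compounds shown do not separate the contribution of the methyl branch from that of the shorter chain, and they give no comparison with the opposite configuration at the defined stereocentre of compound 3. From the compounds shown here alone, how an amine or a carboxylic acid at the end of this chain would read in this assay also remains open.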